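Changing the amine substituent: from difluoromethoxybenzyl to methoxyphenylethyl

The source may hold more compounds than are shown below. What is called first, only, known or untested is meant among the compounds shown, and "the series" means these compounds.

Of the compounds shown here, three built on a shared core have been tested in a toxicity assay on MDCK cells (Canis lupus familiaris) for cytotoxicity, read by crystal violet staining, with a stated time of 48 h; a higher number here means that more compound is tolerated, a lower number that less compound is tolerated. Compound 1 `Cc1ccc2cc(CN(Cc3ccc(C(C)C)cc3)Cc3ccccc3F)c(=O)[nH]c2c1` gives > 33000 nM in this assay, which is a limit of the measurement and not a number. Compound 2 `Cc1ccc2[nH]c(=O)c(CN(Cc3ccc(OC(F)F)cc3)Cc3ccc(C(C)(C)C)cc3)cc2c1` gives > 5000 nM, again only a limit. Compound 3 `CCc1ccc2[nH]c(=O)c(CN(Cc3ccc(OC(F)F)cc3)Cc3ccc(C(C)(C)C)cc3)cc2c1` gives > 5000 nM, also a limit. Compound 3 thus stands at the same limit as compound 2 (the limit of > 5000 nM in this assay, at which 2 of the 3 values shown sit), while compound 1 sits at a different limit (the limit of > 33000 nM in this assay, at which 1 of the 3 values shown sits), so none of the three can be ranked against the others. Going by the values given here, the single measured step, a step that the two limits leave unreadable from compound 2 to compound 3, accordingly has no readable size or direction.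

Compound 4 `CCc1ccc2[nH]c(=O)c(CN(Cc3ccc(C(C)(C)C)cc3)C(C)c3ccc(OC)cc3)cc2c1` has not been measured. It differs from compound 3 by 1-(4-methoxyphenyl)ethyl in place of 4-(difluoromethoxy)benzyl on an amine nitrogen. Among the compounds with values here, no measured step bears on this exchange, and the one step available gives no size at all; the data therefore offer no basis for expecting a change beyond the scatter. Compound 4 is expected to give 20000 nM in this assay, with a range from 5000 nM to 100000 nM. The step this estimate implies, a step that the limit leaves unreadable from compound 3 to compound 4, is expected to stay within the scatter, and a limit rather than a number is the more probable outcome.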

Compound 4, half-maximal cytotoxic concentration: > 5000 nM
Compound 4 ended at the assay's limit; the forecaster's own chance of this, stated with the estimate: 75%; the middle value is on the limit's open side.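

Compound 4 gives > 5000 nM in this assay, which is a limit of the assay and not a number. Going by these compounds alone, compound 3 also stands only at a limit, so no step between compound 3 and compound 4 can be read. The compounds shown leave open where the actual half-maximal cytotoxic concentration of each lies, and whether 1-(4-methoxyphenyl)ethyl in place of 4-(difluoromethoxy)benzyl changes it at all.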